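The source may report more compounds than this note shows. Statements on the series, on what has been measured and on what is new or still open speak of the compounds shown alone.

Compound 1 `CC(=O)Nc1ccc2oc(-c3ccccc3)cc(=O)c2c1` gives 184000 nM in an ADME assay on MT4 cells (Homo sapiens) for cytotoxicity, read by MTT assay, with a stated time of 4 days; on this read-out lower numbers stand for higher toxicity in this test and higher numbers for lower toxicity in this test.
Compound 2 `COc1cccc(-c2cc(=O)c3cc(NC(C)=O)ccc3o2)c1` gives only a limit of this assay, > 404000 nM.
Compound 3 `Nc1ccc2oc(-c3ccccc3)c(O)c(=O)c2c1` gives 217000 nM in this assay.

The change from compound 1 to compound 2 is methoxy in place of hydrogen on an aromatic carbon. It brought an at least 2.1-fold higher number from compound 1 to compound 2 (0.34 log units; beyond the scatter), a step known only as a lower bound because compound 2 sits at the limit of > 404000 nM in this assay, at which 1 of the 3 values shown sits. Compound 3 shares a core with compound 1, but the difference between the two cores is not broken down here; their values in this assay lie within the usual scatter of each other.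

Compound 4 `COc1ccc(-c2oc3ccc(N)cc3c(=O)c2O)cc1` is still unmeasured. It differs from compound 3 by methoxy in place of hydrogen on an aromatic carbon. For the measured compounds named here, this is the same kind of change as the one from compound 1 to compound 2, though the methoxy enters para to a large group rather than meta to a large group. A step similar to an at least 2.1-fold higher number from compound 1 to compound 2 (0.34 log units; beyond the scatter) is expected, so a 1.8-fold higher number from compound 3 to compound 4 (0.24 log units; within the scatter) is estimated. Compound 4 is therefore expected to give about 380000 nM, likely between 200000 nM and 800000 nM, with a fair chance that this assay reports only a limit.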

Compound 4, half-maximal cytotoxic concentration: 239000 nM
Estimate against measurement, compound 4: 1.6-fold (0.20 log units) above; low and high end bracket the measured number.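

On the core of compound 3, the methoxy step is a 1.1-fold higher number from compound 3 to compound 4 (0.04 log units; within the scatter) in this assay and so stays within the usual scatter. Compound 2 gives only a limit, > 404000 nM and not an exact number. The two pairs therefore show neither that the change carries over from one core to the other nor that it fails to, and the comparison stands as follows: the same change on two cores in this assay, an at least 2.1-fold higher number (0.34 log units; beyond the scatter) from compound 1 to compound 2 and a 1.1-fold higher number (0.04 log units; within the scatter) from compound 3 to compound 4; the limit leaves it open whether they differ

The compounds shown leave open how other groups in the same place would behave, such as an ethoxy group, a hydroxyl group or a chlorine atom. They also leave open whether a methoxy elsewhere on this ring would give a different result on either core.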